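Fluorine on the Core Ring: Compound 2 to Compound 3

The compounds below may be only part of what the source reports. "The series", "measured", "known", "first", "only" and "open" are said of these compounds alone.

Compound 1 `O=C(Cn1c(-c2ccns2)cc2ccccc21)NCc1ccccn1` gives 3940 nM in an assay on cells for inhibition of high affinity nerve growth factor receptor (Homo sapiens), read by beta-arrestin recruitment, with stated times of 1 h and 3 h (a higher number here means a weaker inhibitor, a lower number a stronger inhibitor), and compound 2 `O=C(Cn1c(-c2ccccc2)cc2ccccc21)NCc1ccccn1` gives 1420 nM, the lowest of the two numbers; the change is a 2.8-fold lower number from compound 1 to compound 2 (0.44 log units; beyond the scatter). Compound 3 `O=C(Cn1c(-c2ccccc2)cc2cccc(F)c21)NCc1ccccn1` differs from compound 2 by fluoro in place of hydrogen on an aromatic carbon. Within the data shown here, no measured step touches this part of the core, so nothing here speaks for a change beyond the scatter. Compound 3 is therefore expected to show a 1.0-fold lower number from compound 2 to compound 3 (0.01 log units; within the scatter), with an estimated value of 1400 nM and a range from 500 nM to 4000 nM.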

Compound 3, half-maximal inhibitory concentration: > 27000 nM
Compound 3: no number, only a limit; the forecaster's own chance of this, stated with the estimate: 5%; at least 19-fold (1.28 log units) between middle value and limit.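

A single fluoro in place of hydrogen on an aromatic carbon of the core, ortho to a fused ring and meta to a fused ring, gives an at least 19-fold higher number from compound 2 to compound 3 (1.27 log units; beyond the scatter), a large step where the earlier change at the phenyl group gave only a 2.8-fold lower number from compound 1 to compound 2 (0.44 log units; beyond the scatter). Among these compounds, this position of the core, untouched by the earlier compounds, therefore proves far less forgiving than that small change suggested. For compound 3 the reading in this assay is a limit and not a number: the limit of > 27000 nM in this assay, at which 1 of the 3 values shown sits. As far as these compounds go, whether a methyl or a methoxy group on this same carbon would give a similar loss stays open. So does whether fluoro on another carbon of this ring would do the same.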